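Chloro on the phenyl tail of compound 3

A few compounds are considered here, and "the series" means these few. Any claim that something is new, unique, unknown or untested is made for them only; others in the source may bear on it.

In an in vitro assay on cells for inhibition of Amine oxidase [flavin-containing] B (Homo sapiens), read by fluorescence and Amplex Red, with stated times of 30 min and 45 min (on this read-out lower numbers stand for stronger inhibition and higher numbers for weaker inhibition), compound 3 `O=C(CCCc1ccccc1)Nc1nc2ccccc2c(=O)s1` gives 34.9 nM, the lowest of the two numbers shown; compound 2 `COc1cccc(/C=C/C(=O)Nc2nc3ccccc3c(=O)s2)c1` gives 470 nM in this assay. Compound 1 `O=C(CCCc1ccccc1)Nc1nc2ccc(Cl)cc2c(=O)s1` reports only a limit of this assay, > 10000 nM. Compound 4 `O=C(CCCc1cccc(Cl)c1)Nc1nc2ccccc2c(=O)s1` differs from compound 3 by chloro in place of hydrogen on an aromatic carbon. Within the data shown here, the only measured step that moves a chloro is an at least 280-fold lower number from compound 1 to compound 3 (2.45 log units; beyond the scatter), on the shared core rather than on the phenyl tail; its true size is uncertain due to the limit of > 10000 nM in this assay, at which 1 of the 3 values shown sits. Among the measured compounds shown here, no measured step touches the phenyl tail itself, so nothing forces a change beyond the scatter. The expected step is a 1.2-fold lower number from compound 3 to compound 4 (0.07 log units; within the scatter). Compound 4 is estimated at 30 nM, range 8 nM to 120 nM.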

Compound 4, half-maximal inhibitory concentration: > 1000 nM
Compound 4: no number, only a limit (the forecaster's own chance of this, stated with the estimate: 3%); at least 33-fold (1.52 log units) between middle value and limit.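

The phenyl tail is sensitive to this change: in this assay, 3-chlorophenyl in place of phenyl gives an at least 28-fold higher number from compound 3 to compound 4 (1.45 log units; beyond the scatter). Chloro on the tail in compound 4, like chloro on the shared core in compound 1, therefore goes with weaker inhibition than compound 3 shows. The value of compound 4 is a limit, so the full size of the step cannot be read due to that limit: the limit of > 1000 nM in this assay, at which 1 of the 4 values shown sits.

Going by these compounds, whether the loss belongs to chloro itself or to any group at this place stays open. Fluoro or methyl on the tail, or chloro on another carbon of the tail, would separate these readings.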